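A few compounds are considered here, and "the series" means these few. Any claim that something is new, unique, unknown or untested is made for them only; others in the source may bear on it.

In a functional assay on HCT-116 cells (Homo sapiens) for antiproliferative activity, read by MTT assay, with a stated time of 72 h (on this read-out lower numbers stand for stronger inhibition and higher numbers for weaker inhibition), three compounds that share one core have been measured. Compound 1 `CN(C(=O)c1ccccc1)c1ccc2[nH]c(-c3n[nH]c4ccccc34)cc2n1` gives 10600 nM. Compound 2 `CN(C(=O)c1ccc(F)cc1)c1ccc2[nH]c(-c3n[nH]c4ccccc34)cc2n1` carries a fluoro in place of hydrogen on an aromatic carbon and gives 9270 nM; the change a 1.1-fold lower number from compound 1 to compound 2 (0.06 log units; within the scatter) stays within the scatter. Compound 3 `CN(C(=O)c1ccc(Cl)cc1)c1ccc2[nH]c(-c3n[nH]c4ccccc34)cc2n1` carries a chloro at the same place and gives 3000 nM; the steps of a 3.5-fold lower number from compound 1 to compound 3 (0.55 log units; beyond the scatter) and a 3.1-fold lower number from compound 2 to compound 3 (0.49 log units; beyond the scatter) are both modest but beyond the scatter, so compound 3 stands lowest of the three numbers, that is, as the strongest inhibitor so far.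

Compound 4 `COc1ccc(C(=O)N(C)c2ccc3[nH]c(-c4n[nH]c5ccccc45)cc3n2)cc1` differs from compound 3 by methoxy in place of chloro on an aromatic carbon. Among the measured compounds shown here, none of the measured steps involves a methoxy, so the only guidance is that a halogen at this place gave at best a modest lowering of the number, and that the smallest halogen gave none beyond the scatter. A methoxy is therefore expected to land somewhere between the values of compound 1 and compound 3 rather than below compound 3. The expected step of a 2.0-fold higher number from compound 3 to compound 4 (0.30 log units; within the scatter) points toward a higher number, meaning weaker inhibition. For compound 4 the estimate in this assay is 6000 nM, with a range from 2500 nM to 15000 nM.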

Compound 4, half-maximal inhibitory concentration: 29500 nM
For compound 4 the middle estimate is 4.9-fold (0.69 log units) below the measured one; the whole stated range lies below it.
By their numbers in this assay, from the lowest: compound 3; then compounds 2 and 1 (each within the scatter of the next); then compound 4.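

In this assay, among the compounds shown here, compound 4 is the first case where a group at this place, para to a large group, raises the number beyond the scatter relative to plain hydrogen, with a 2.8-fold higher number from compound 1 to compound 4 (0.44 log units; beyond the scatter). For the compounds shown here, the place therefore works in both directions: chloro lowers the number and methoxy raises it, so replacing one with the other gives a 9.8-fold higher number from compound 3 to compound 4 (0.99 log units; beyond the scatter), a wider step than any seen among the earlier compounds, while methoxy against fluoro gives a 3.2-fold higher number from compound 2 to compound 4 (0.50 log units; beyond the scatter). No measurement at hand explains why these two groups pull in opposite directions.

The compounds shown leave open where a bromo, a methyl, an ethoxy or an amine at this same place would fall, and so whether the order seen here would hold for a wider set of groups. They also leave open whether chloro and methoxy would keep these opposite directions if they were attached elsewhere on the six-membered ring, or on a compound with a different core.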